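The source may hold more compounds than are shown below. What is called first, only, known or untested is meant among the compounds shown, and "the series" means these compounds.

Working notes on the series. Compound 1 `O=C(NCc1ccc(S(=O)(=O)c2ccccc2)cc1)N1CCc2ccncc2C1` was run in a functional assay on A2780 cells (Homo sapiens) for cytotoxicity, read by sulforhodamine B assay, with a stated time of 72 h; a lower number here means a stronger inhibitor, a higher number a weaker inhibitor. In this assay compound 1 returns only a limit, > 2000 nM. Compound 2 `O=S(=O)(c1ccccc1)c1ccc(CNS(=O)(=O)N2Cc3ccncc3C2)cc1` likewise returns only a limit in this assay, > 2000 nM. Among the measured compounds shown here, compound 3 `O=C(NCc1ccc(S(=O)(=O)c2cc(F)cc(F)c2)cc1)N1Cc2ccncc2C1` is the single member with a number: in this assay compound 3 gives 6.3 nM. For the measured compounds named here, it therefore stands alone at the potent end of what has been recorded, while the rest of the set sits at the limit of > 2000 nM in this assay, at which 2 of the 3 values shown sit, so no measured step between two numbers exists here and no size of effect for any single change can be read off.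

Compound 4 `O=C(NCc1ccc(S(=O)(=O)N2CCC(O)CC2)cc1)N1Cc2ccncc2C1` has not yet been tested in this assay. Set against compound 3 it differs in one place: 4-hydroxypiperidin-1-yl in place of 3,5-difluorophenyl on a sulfonyl sulfur. Going by the values given here, every compound measured so far carries an aromatic ring on that sulfonyl sulfur. Among the compounds with values here, no recorded step covers 4-hydroxypiperidin-1-yl in that place. The expectation is a loss of potency from compound 3 to compound 4 of about a 48-fold higher number from compound 3 to compound 4 (1.68 log units; beyond the scatter), clearly beyond the scatter. Compound 4 is thus estimated at 300 nM, with a plausible range from 30 nM to 2000 nM.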

Compound 4, half-maximal inhibitory concentration: 98 nM
Compound 4: the middle estimate sits 3.1-fold (0.49 log units) above what was measured; low and high end bracket the measured number.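

In this assay, the place on a sulfonyl sulfur proves open to a non-aromatic ring: compound 4, with 4-hydroxypiperidin-1-yl in place of 3,5-difluorophenyl, still gives a number, 98 nM, and the change costs a 16-fold higher number from compound 3 to compound 4 (1.19 log units; beyond the scatter). Among the compounds shown here, until now, every compound measured carried an aromatic ring at this place, so the series held no measured step for this position and no size for any change made there; this step is the first, and it shows that the position matters to potency while an aromatic ring there is not needed for a value in the measurable range. The other steps cannot be read, as compound 1 and compound 2 each return only a limit and not a number: the limit of > 2000 nM in this assay, at which 2 of the 4 values shown sit.

For the compounds shown here, the single step changes the aromatic character of the ring, the ring atoms and the hydroxyl together, so it does not show which of these carries the loss; a plain piperidin-1-yl or a morpholin-4-yl at the same place would separate them. Also open, as far as these compounds go, is what 3,5-difluorophenyl itself contributes, which an unsubstituted phenyl on the core of compound 3 would address.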